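The compounds below may be only part of what the source reports. "The series", "measured", "known", "first", "only" and "open" are said of these compounds alone.

The measured compounds in this set:
compound 1 `Cc1cc(CCC#N)cc(C)c1Oc1cc(Nc2ccc(C#N)cc2)c(N)cc1CN(C)C` gives 23800 nM
compound 2 `Cc1cc(CCC#N)cc(C)c1Oc1cc(Nc2ccc(C#N)cc2)c(N)cc1CNC1CC1` gives 25500 nM

In an ADME assay on TZM cells (Homo sapiens) for cytotoxicity, with a stated time of 1 days (a lower number here means that less compound is tolerated, a higher number that more compound is tolerated), compound 2 stands at the higher of the two numbers, with compound 1 the nearest and only other point. Within the data shown here, the single step between them, a 1.1-fold higher number from compound 1 to compound 2 (0.03 log units; within the scatter), lies within the scatter, so the two are not distinguished.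

Compound 3 `CNC(=O)OCc1cc(N)c(Nc2ccc(C#N)cc2)cc1Oc1c(C)cc(CCC#N)cc1C` has not yet been measured in this assay. It differs from compound 2 by (methylcarbamoyl)oxy in place of cyclopropylamino on a saturated chain carbon bound to an aromatic carbon. Among the measured compounds shown here, the only measured step that bears on a change at this place is a 1.1-fold higher number from compound 1 to compound 2 (0.03 log units; within the scatter), which was too small to count. With one such step and no further data, no movement beyond the scatter is expected for compound 3 in this assay. Compound 3 is therefore expected to give about 25000 nM, within 10000 nM to 60000 nM, the expected step being a 1.0-fold lower number from compound 2 to compound 3 (0.01 log units; within the scatter).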

Compound 3, half-maximal cytotoxic concentration: 46800 nM
The estimate for compound 3 lay 1.9-fold (0.27 log units) below the measured number, and the stated range covers the measured number.
By their numbers in this assay, from the lowest: compounds 1, 2 and 3 (each within the scatter of the next).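

In this assay, the earlier pair had exchanged only one amine for another on a saturated chain carbon bound to an aromatic carbon, whereas compound 3 carries (methylcarbamoyl)oxy there, with no amine on that carbon and no ring in the group. Even so, the result is a 1.8-fold higher number from compound 2 to compound 3 (0.26 log units; within the scatter) and a 2.0-fold higher number from compound 1 to compound 3 (0.29 log units; within the scatter), so this wider exchange is not distinguished from either amine, and all three compounds remain within the scatter of the next. No supporting measurement accompanies these numbers to explain them.

On these data alone, it remains open whether a carboxylic acid or a longer chain at this place would give a number beyond the scatter. As far as these compounds go, it is also open whether the same exchange would read alike with a different group elsewhere on the shared core.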